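The source may hold more compounds than are shown below. What is called first, only, known or untested is meant among the compounds shown, and "the series" means these compounds.

Four compounds share a core. Compound 1 `Cc1nn(C)c2c1C(c1ccccc1)=NCCN2CCCN(C)C` and compound 2 `Cc1cccc(C2=NCCNc3c2c(C)nn3C)c1` differ in more than one place, and the difference between the two cores is not broken down here. In a functional assay on the whole organism for positive allosteric modulation, with Rattus norvegicus as the target (on this read-out higher numbers stand for an effect only at larger amounts of compound and lower numbers for an effect already at smaller amounts), compound 1 gives only a limit, > 10 mg/kg. Compound 3 `Cc1cccc(C2=NCCN(CCCN(C)C)c3c2c(C)nn3C)c1` likewise gives only a limit in this assay, > 10 mg/kg. Among the compounds with values here, compound 2 gives 2.5 mg/kg in this assay, the only number among the three. Adding 3-(dimethylamino)propyl on a nitrogen on an aromatic ring in a ring yields an at least 4.0-fold higher number from compound 2 to compound 3 (0.60 log units; beyond the scatter). The change methyl in place of hydrogen on an aromatic carbon gives a step that the two limits leave unreadable from compound 1 to compound 3, unreadable because of the limit of > 10 mg/kg in this assay, at which 2 of the 3 values shown sit. Compound 4 `Cc1cc(C)cc(C2=NCCNc3c2c(C)nn3C)c1` arises from compound 2 by methyl in place of hydrogen on an aromatic carbon, the same kind of change, though here the place is also meta to a methyl group. With that step unreadable, compound 4 is expected near compound 2, estimated at 2.5 mg/kg, a step of no change at the digits printed from compound 2 to compound 4 (within the scatter), within 1 mg/kg to 10 mg/kg.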

Compound 4, minimum effective dose: > 10 mg/kg
Compound 4 was reported as a limit; the forecaster's own chance of this, stated with the estimate: 25%; middle value at least 4.0-fold (0.60 log units) away from the limit.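

On the core of compound 2, methyl in place of hydrogen on an aromatic carbon gives an at least 4.0-fold higher number from compound 2 to compound 4 (0.60 log units; beyond the scatter) in this assay, so on this core an effect needs larger amounts of compound. From the compounds shown here alone, compound 4 gives only a limit, > 10 mg/kg, so the exact size of this step stays unknown. The same kind of change on the core of compound 1 cannot be read, so nothing here shows whether it carries from one core to the other, because so many values are limits: the limit of > 10 mg/kg in this assay, at which 3 of the 4 values shown sit.

Open, going by these compounds, is how a chlorine atom or an amine in place of that hydrogen would behave in this assay. Also open, on these data alone, is whether the methyl's effect depends on its place, here meta to a methyl group.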